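The compounds below may be only part of what the source reports. "The series", "measured", "known", "first", "only" and "open" are said of these compounds alone.

Of the compounds shown here, two sharing one core have been measured in a functional assay on HepG2 cells (Homo sapiens) for antiproliferative activity, read by MTT assay, with a stated time of 72 h (a higher number here means a weaker inhibitor, a lower number a stronger inhibitor), so far. Compound 1 `O=C(N/N=C/c1cccc(Br)c1)Nc1ccc(Oc2ccnc3[nH]ccc23)c(F)c1` carries a 3-bromophenyl group on the carbon that is double-bonded to nitrogen, and in this assay compound 1 gives 660 nM. Compound 2 `O=C(N/N=C/c1ccc(F)cc1)Nc1ccc(Oc2ccnc3[nH]ccc23)c(F)c1` carries a 4-fluorophenyl group in the same place, and in this assay compound 2 gives 3880 nM. For the measured compounds named here, on these two numbers compound 2 stands highest, that is, it is the weaker inhibitor of the pair, and the single step between them, a 5.9-fold higher number from compound 1 to compound 2 (0.77 log units; beyond the scatter), lies beyond the scatter.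

Compound 3 `O=C(N/N=C/c1cc(Br)c(O)c(Br)c1)Nc1ccc(Oc2ccnc3[nH]ccc23)c(F)c1` is not yet measured. Its structure differs from compound 2 as follows: 3,5-dibromo-4-hydroxyphenyl in place of 4-fluorophenyl on a carbon with a double bond to nitrogen. Going by the values given here, the one step that bears on this change is a 5.9-fold higher number from compound 1 to compound 2 (0.77 log units; beyond the scatter), where swapping bromine for fluorine on that ring weakened inhibition by a modest amount. Among the compounds with values here, compound 3 puts bromine back onto the ring, twice, and adds a hydroxyl group, so a return toward a lower number seems likely, though the hydroxyl has no precedent among the measured compounds. Compound 3 is therefore expected to come in near 600 nM, with a range from 150 nM to 2500 nM. That would mean an estimated step of a 6.5-fold lower number from compound 2 to compound 3 (0.81 log units; beyond the scatter).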

Compound 3, half-maximal inhibitory concentration: 6520 nM
Compound 3: the middle estimate sits 11-fold (1.04 log units) below what was measured, outside the stated range (above it).
By their numbers in this assay, from the lowest: compound 1; then compounds 2 and 3 (each within the scatter of the next).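

In this assay the change to 3,5-dibromo-4-hydroxyphenyl on the carbon with a double bond to nitrogen gives a 1.7-fold higher number from compound 2 to compound 3 (0.23 log units; within the scatter) and so leaves compound 2 and compound 3 indistinguishable, which shows that this larger group, with its hydroxyl and two bromine atoms, does not restore the lower number seen with 3-bromophenyl. Carrying bromine on this ring is therefore not enough to give a low number: the comparison with 3-bromophenyl is a 9.9-fold higher number from compound 1 to compound 3 (0.99 log units; beyond the scatter) and keeps compound 1 the strongest inhibitor of the three, even though compound 3 carries bromine too. No measurement at hand explains why these ring groups rank as they do.

Compound 3 brings in its hydroxyl together with its bromine atoms, and no compound shown carries a hydroxyl on this ring without bromine, so what each contributes to the number stays open. Also open, as far as these compounds go, is how this position would respond to a ring bearing an amine or a carboxylic acid, or to a plain unsubstituted phenyl.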